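This account rests on a few compounds, and the source may have more. Where it says the series, first, only, none or still open, it means among the compounds named here.

The measured compounds, in a functional assay on ACHN cells (Homo sapiens) for cytotoxicity, read by sulforhodamine B assay, with a stated time of 72 h; a lower number here means a stronger inhibitor of growth, a higher number a weaker inhibitor of growth:

Compound 1, `O=C(Nc1ccccc1O)C1CCc2ccccc2N1C(=O)c1ccccc1Cl`, gives 44200 nM.
Compound 2, `CCCC(=O)N1c2ccccc2CCC1C(=O)Nc1ccccc1C(F)(F)F`, gives only a limit, > 70000 nM.
Compound 3, `CCC(=O)N1c2ccccc2CCC1C(=O)Nc1ccccc1C(F)(F)F`, gives only a limit, > 80000 nM.

Compound 3 stands at the upper limit of this assay, with no number of its own. Among the compounds with values here, the one measured step leading to it, a step that the two limits leave unreadable from compound 2 to compound 3, runs from one limit to another and gives no readable size, which is evidence of the limit of > 70000 nM in this assay, at which 1 of the 3 values shown sits, and the limit of > 80000 nM in this assay, at which 1 of the 3 values shown sits, only. The step to compound 4, `O=C(Nc1ccccc1C(F)(F)F)C1CCc2ccccc2N1C(=O)c1ccc(Cl)cc1`, is 4-chlorophenyl in place of ethyl on a carbonyl carbon, so that propanoyl becomes (4-chlorophenyl)carbonyl on the same core. Within the data shown here, no measured step covers this change; compound 1, which carries a chlorophenyl carbonyl on the ring nitrogen but a different amide, gives a number below the limits, though it differs from compound 3 in two places and supports no single step. On that footing the step of an at least 1.6-fold lower number from compound 3 to compound 4 (0.20 log units; that floor lies within the scatter) is expected to bring compound 4 down from the limit, and compound 4 is estimated at 50000 nM, within 15000 nM to 150000 nM.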

Compound 4, concentration for 50% growth inhibition: 824 nM
Compound 4: the middle estimate sits 61-fold (1.78 log units) above what was measured; measured number below the stated range.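

Putting 4-chlorophenyl in place of ethyl on a carbonyl carbon, with the rest of the molecule unchanged, gives an at least 97-fold lower number from compound 3 to compound 4 (1.98 log units; beyond the scatter) in this assay, and putting it in place of propyl gives an at least 84-fold lower number from compound 2 to compound 4 (1.92 log units; beyond the scatter). The two short chains had shown only limits, so these are the first readable steps at this place, and they show that the group on this carbonyl carbon can change growth inhibition strongly. Both sizes are floors rather than exact sizes, since each step starts from a limit of the assay: the limit of > 70000 nM in this assay, at which 1 of the 4 values shown sits, and (the limit of > 80000 nM in this assay, at which 1 of the 4 values shown sits).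

The compounds shown do not separate the chlorine from the aromatic ring, which a plain phenyl or a cyclohexyl on this carbonyl carbon would do. From the compounds shown here alone, whether a methoxy group or an amine could take the place of the chlorine also remains open.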